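Chlorine Added to a Serotonin Receptor Ligand

The source may report more compounds than this note shows. Statements on the series, on what has been measured and on what is new or still open speak of the compounds shown alone.

Compound 1 `CCCCN1CCC(CNC(=O)c2cc(Cl)c(N)c3[nH]cnc23)CC1`: 22.4 nM
Compound 2 `CCCCN1CCC(CNC(=O)c2ccc(N)c3[nH]cnc23)CC1`: 115 nM
Compound 3 `CS(=O)(=O)NCCN1CCC(COC(=O)c2cccc3[nH]cnc23)CC1`: 26.3 nM

These three compounds were tested in an assay on membranes from striatum with 5-hydroxytryptamine receptor 4 (Rattus norvegicus) as the target; a higher number here means a weaker inhibitor, a lower number a stronger inhibitor. Compound 1 differs from compound 2 by chloro in place of hydrogen on an aromatic carbon, and that change gave a 5.1-fold lower number from compound 2 to compound 1 (0.71 log units; beyond the scatter). Compound 3 shares much with them, but the difference between the two cores is not broken down here. Compound 4 `CS(=O)(=O)NCCN1CCC(COC(=O)c2cc(Cl)cc3[nH]cnc23)CC1` has not yet been measured; it differs from compound 3 by chloro in place of hydrogen on an aromatic carbon. This is the same kind of change as before, not the same: in compound 1 the chloro is ortho to an amino group, and compound 4 has no such group. In this assay compound 4 is therefore expected to show a 2.4-fold lower number from compound 3 to compound 4 (0.38 log units; beyond the scatter), a smaller gain than a 5.1-fold lower number from compound 2 to compound 1 (0.71 log units; beyond the scatter). Compound 4 is estimated at 11 nM, between 4 nM and 30 nM.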

Compound 4, inhibition constant: 2.29 nM
Estimate against measurement, compound 4: 4.8-fold (0.68 log units) above, and the stated range ends above it.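

In this assay, chloro in place of hydrogen gave an 11-fold lower number from compound 3 to compound 4 (1.06 log units; beyond the scatter) on this second core, so the gain seen on the first core also appears here. The step looks larger on this core, but the two steps cannot be told apart : the same change on two cores in this assay, a 5.1-fold lower number (0.71 log units; beyond the scatter) from compound 2 to compound 1 and an 11-fold lower number (1.06 log units; beyond the scatter) from compound 3 to compound 4, 2.2-fold (0.35 log units) apart, within the scatter of two such steps. This shows that the change carried across these two pairs, but two pairs cannot show that it will carry to every core in the series, and they do not explain why it helps.

From the compounds shown here alone, it remains open whether fluoro, bromo or a methyl group in the same place would do as well as chloro. Going by these compounds, it also remains open whether chloro would give a similar step at another carbon of the aromatic ring.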